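The source may report more compounds than this note shows. Statements on the series, on what has been measured and on what is new or still open speak of the compounds shown alone.

In a functional assay on HeLa cells (Homo sapiens) for inhibition, read by MTT assay, with a stated time of 48 h (a lower number here means a stronger inhibitor, a higher number a weaker inhibitor), compound 1 `COc1cccc(C(c2c[nH]c3ccc(Br)cc23)c2c[nH]c3ccc(Br)cc23)c1OC` gives 64500 nM, and compound 2 `Brc1ccc2[nH]cc(C(c3c[nH]c4ccc(Br)cc34)C3CCCCC3)c2c1` gives 3200 nM, the lower of the two numbers and so the stronger inhibition. Compound 3 `CCCC(c1c[nH]c2ccc(Br)cc12)c1c[nH]c2ccc(Br)cc12` has not yet been measured. It carries propyl in place of cyclohexyl on a saturated chain carbon bound to two aromatic carbons. Among the compounds with values here, only one measured step bears on this change, and it lies at the same carbon: a 20-fold lower number from compound 1 to compound 2 (1.30 log units; beyond the scatter), large and beyond the scatter, with cyclohexyl in place of 2,3-dimethoxyphenyl. That step shows that the group on this carbon can matter a great deal, but no open chain has been tested there. A modest rise in the number is therefore expected, much smaller than that step. The expected step is a 2.2-fold higher number from compound 2 to compound 3 (0.34 log units; beyond the scatter). Compound 3 is estimated at 7000 nM, with an expected range from 1800 nM to 28000 nM.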

Compound 3, half-maximal inhibitory concentration: 3900 nM
For compound 3 the middle estimate is 1.8-fold (0.25 log units) above the measured one; the measured number falls inside the stated range.
By their numbers in this assay, from the lowest: compounds 2 and 3 (each within the scatter of the next); then compound 1.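

In this assay, the step from the cyclohexyl ring to the open propyl chain, a 1.2-fold higher number from compound 2 to compound 3 (0.09 log units; within the scatter), is too small to separate compound 2 from compound 3, so a ring on this carbon is not needed to keep this level of inhibition. The step of a 17-fold lower number from compound 1 to compound 3 (1.22 log units; beyond the scatter) is close in size to the earlier step of a 20-fold lower number from compound 1 to compound 2 (1.30 log units; beyond the scatter), which means that two differently shaped carbon groups in place of 2,3-dimethoxyphenyl both give a much lower number than compound 1. Nothing measured here explains these results.

Going by these compounds, it remains open how far the chain length can vary, for instance with a methyl group or a longer hexyl chain. It is also unclear how a propyl chain ending in an amine or a carboxylic acid would behave at this carbon.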